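Replacing a Hexylsulfanyl Chain with a tert-Butylphenyl Ring

This account rests on a few compounds, and the source may have more. Where it says the series, first, only, none or still open, it means among the compounds named here.

Compound 2 `CCCCCCSc1cc(C(F)(F)F)ccc1CNC(=O)C(C)c1ccc(NS(C)(=O)=O)c(F)c1` gives 1.8 nM in an assay on CHO cells for antagonist activity at transient receptor potential cation channel subfamily V member 1 (Homo sapiens), read by FLIPR; on this read-out higher numbers stand for weaker inhibition and lower numbers for stronger inhibition. Among the measured compounds shown here, of the two compounds measured, compound 2 carries the higher number; its only neighbour, compound 1 `CC(C(=O)NCc1ccc(C(F)(F)F)cc1OC1CCCCC1)c1ccc(NS(C)(=O)=O)c(F)c1`, gives 0.7 nM in this assay. For the measured compounds named here, the single measured step, a 2.6-fold higher number from compound 1 to compound 2 (0.41 log units; beyond the scatter), is the only precedent for altering the group at this aromatic carbon, and it shows that such an exchange moves the number by a modest amount.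

Compound 3 `CC(C(=O)NCc1ccc(C(F)(F)F)cc1-c1ccc(C(C)(C)C)cc1)c1ccc(NS(C)(=O)=O)c(F)c1` has not yet been measured. It differs from compound 2 by 4-(tert-butyl)phenyl in place of hexylsulfanyl on an aromatic carbon. Going by the values given here, no measured pair exchanges a chain for an aromatic ring at this position, so the direction of the step cannot be read from the data. On the strength of the modest step seen before, the step of a 1.2-fold lower number from compound 2 to compound 3 (0.08 log units; within the scatter) is expected to stay small, within the scatter or slightly beyond it. Compound 3 is therefore expected to give 1.5 nM in this assay, with a range from 0.4 nM to 6 nM.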

Compound 3, inhibition constant: 1.1 nM
Estimate against measurement, compound 3: 1.4-fold (0.13 log units) above, and the stated range covers the measured number.
By their numbers in this assay, from the lowest: compounds 1, 3 and 2 (each within the scatter of the next, the first and the last beyond it).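

In this assay, 4-(tert-butyl)phenyl in place of hexylsulfanyl gives a 1.6-fold lower number from compound 2 to compound 3 (0.21 log units; within the scatter) and the same group in place of cyclohexyloxy gives a 1.6-fold higher number from compound 1 to compound 3 (0.20 log units; within the scatter) so both exchanges stay within the scatter. The earlier compounds shown here showed only groups joined through sulfur or oxygen, whereas compound 3 shows that an aromatic ring of carbon only, set directly on this aromatic carbon ortho to a large group and meta to a trifluoromethyl group, also keeps the number within the scatter of both neighbours. Nothing measured here gives a reason for this result.

The compounds shown leave open how far this tolerance extends to a ring bearing an amine or a carboxylic acid in place of tert-butyl. They also leave open how an unsubstituted phenyl ring or a pyridine ring would read at this position.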